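This account rests on a few compounds, and the source may have more. Where it says the series, first, only, none or still open, it means among the compounds named here.

Working notes on the series. The shared core is that of compound 1 `Cc1nn([C@H](C)c2ccc(Cl)cc2Cl)c2nc(N3CC[C@H](N4CCC[C@H]4C(N)=O)[C@H](C)C3)cnc12`; in an assay on CCRF-CEM cells for antagonist activity at C-C chemokine receptor type 4 (Homo sapiens), read by CellTiter-Glo, with stated times of 30 min and 60 min, in the presence of a further agent that is not named here (a higher number here means a weaker inhibitor, a lower number a stronger inhibitor), compound 1 stands as "not determined" (no result reported). Compound 2 `C[C@@H]1CC(c2cnc3c(C#N)nn([C@H](C)c4ccc(Cl)cc4Cl)c3n2)=CC[C@@H]1N1CCC[C@H]1CO` gives 70 nM in this assay, and compound 3 `Cc1nn([C@H](C)c2ccc(Cl)cc2Cl)c2nc(C3=CC[C@H](N4CCC[C@H]4CO)[C@H](C)C3)cnc12` gives 179 nM. Among the compounds with values here, of these two numbers, compound 2 holds the lower one; the only step on record, a 2.6-fold higher number from compound 2 to compound 3 (0.41 log units; beyond the scatter), lies on an aromatic carbon. Compound 4 `C[C@@H]1CC(c2cnc3c(C#N)nn([C@H](C)c4ccc(Cl)cc4Cl)c3n2)=CC[C@@H]1N1CCC[C@H]1C` differs from compound 2 by hydrogen in place of hydroxy on a saturated chain carbon bound to a saturated ring carbon, read one bond further out as 2-(hydroxymethyl)pyrrolidin-1-yl to 2-methylpyrrolidin-1-yl. Within the data shown here, no measured step touches this position, so the direction is open and only a modest shift is assumed. Compound 4 is expected at 150 nM, within 50 nM to 500 nM. The expected step is a 2.1-fold higher number from compound 2 to compound 4 (0.33 log units; beyond the scatter).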

Compound 4, half-maximal inhibitory concentration: 44 nM
Compound 4: the middle estimate sits 3.4-fold (0.53 log units) above what was measured; the measured number lies below the stated range.
By their numbers in this assay, from the lowest: compounds 4 and 2 (each within the scatter of the next); then compound 3.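

On the saturated chain carbon bound to a saturated ring carbon, hydrogen in place of hydroxy gives a 1.6-fold lower number from compound 2 to compound 4 (0.20 log units; within the scatter) in this assay for this pair. The hydroxy of 2-(hydroxymethyl)pyrrolidin-1-yl is therefore not needed to keep a value of this order, since 2-methylpyrrolidin-1-yl keeps it with the cyano compounds. No evidence is available on why the two compounds read alike. Going by these compounds, whether an amine, a carboxylic acid or a longer chain at this carbon would hold the value remains open. Also open, on these data alone, is whether the same change reads alike with methyl in place of cyano on the aromatic carbon.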